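The source may report more compounds than this note shows. Statements on the series, on what has been measured and on what is new or still open speak of the compounds shown alone.

In an assay for inhibition of tyrosine-protein kinase Mer (Homo sapiens), read by 33P incorporation, in the presence of a further agent that is not named here (on this read-out lower numbers stand for stronger inhibition and higher numbers for weaker inhibition), compound 2 `CCN1CCN(c2ccc(-c3nn(CC4CCCC4)c4nc(NC)ncc34)cn2)CC1` gives 2500 nM, the lowest of the two numbers in hand. Compound 1 `CNc1ncc2c(-c3ccc(N4CCN(C(=O)C(C)(C)C)CC4)nc3)nn(Cc3cn(Cc4ccccc4)nn3)c2n1` gives 5400 nM in this assay; the two structures differ in more than one place, so the gap between them, which lies beyond the scatter, cannot be tied to a single change. Compound 3 `CNc1ncc2c(-c3ccc(N4CCN(C(=O)C(C)(C)C)CC4)nc3)nn(CC3CCCC3)c2n1` has not yet been measured in this assay. It differs from compound 2 in one place: (tert-butyl)carbonyl in place of ethyl on an amine nitrogen in a ring, the same group that compound 1 carries on its ring. Going by the values given here, compound 1 is the only measured compound with this group, and it carries a second difference as well, so the change itself has not been isolated. The step of a 1.2-fold higher number from compound 2 to compound 3 (0.08 log units; within the scatter) is expected to be small, with no clear direction beyond the scatter. Compound 3 is therefore expected to give about 3000 nM, with a range from 1000 nM to 9000 nM.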

Compound 3, half-maximal inhibitory concentration: > 10000 nM
Compound 3: no number, only a limit (the forecaster's own chance of this, stated with the estimate: 5%); middle value at least 3.3-fold (0.52 log units) from the limit.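

Taken on its own for the first time, (tert-butyl)carbonyl in place of ethyl on the amine nitrogen in the ring gives an at least 4.0-fold higher number from compound 2 to compound 3 (0.60 log units; beyond the scatter), so in this assay this change weakens inhibition beyond the scatter. Cyclopentyl in place of 1-benzyl-1H-1,2,3-triazol-4-yl on the saturated chain carbon bound to an aromatic nitrogen gives an at least 1.8-fold higher number from compound 1 to compound 3 (0.26 log units; that floor lies within the scatter), a floor within the scatter, so with (tert-butyl)carbonyl on the ring nitrogen these two groups cannot be put in order. Compound 3 gives a limit of the assay and not a number, so both steps are floors and their full size is unknown: the limit of > 10000 nM in this assay, at which 1 of the 3 values shown sits.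

Going by these compounds, what remains open is whether the weakening belongs to the carbonyl or to the tert-butyl, which acetyl or a plain neopentyl chain on that nitrogen could separate. On these data alone, it is also open whether ethyl on that nitrogen would behave the same way alongside 1-benzyl-1H-1,2,3-triazol-4-yl.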